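The source may report more compounds than this note shows. Statements on the series, on what has been measured and on what is new or still open speak of the compounds shown alone.

Working notes on the series. Compound 1 `COC(=O)/C=C/c1ccc(CN(C(=O)C2CCCCC2)c2cccc(/C=C/C(=O)OC)c2)cc1` is taken as the starting point. In an assay on isolated protein with Bile acid receptor (Homo sapiens) as the target (on this read-out lower numbers stand for an effect already at smaller amounts and higher numbers for an effect only at larger amounts of compound), compound 1 gives only a limit, > 1000 nM. Compound 2 `CCOC(=O)/C=C/c1ccc(CN(C(=O)C2CCCCC2)c2cccc(/C=C/C(=O)OC)c2)cc1` differs from compound 1 by methyl in place of hydrogen on a saturated chain carbon bound to an oxygen next to a carbonyl group. In this assay compound 2 likewise gives only a limit, > 1000 nM. The step that the two limits leave unreadable from compound 1 to compound 2, because of the limit of > 1000 nM in this assay, at which 2 of the 3 values shown sit. Compound 3 `COC/C=C/c1ccc(CN(C(=O)C2CCCCC2)c2cccc(/C=C/C(=O)OC)c2)cc1` differs from compound 1 by methoxymethyl in place of methoxycarbonyl on a double-bonded chain carbon bound to a double-bonded chain carbon. In this assay compound 3 gives 233 nM, and the steps of an at least 4.2-fold lower number from compound 1 to compound 3 (0.63 log units; beyond the scatter) and an at least 4.2-fold lower number from compound 2 to compound 3 (0.63 log units; beyond the scatter) are the only readable ones. Compound 4 `CCOC/C=C/c1ccc(CN(C(=O)C2CCCCC2)c2cccc(/C=C/C(=O)OC)c2)cc1`, not yet measured, differs from compound 3 by methyl in place of hydrogen on a saturated chain carbon bound to an oxygen on a saturated carbon. This is the same kind of change as that from compound 1 to compound 2, but the place differs: there the carbon is bound to an oxygen next to a carbonyl group, here to an oxygen on a saturated carbon; the cores differ by the change already given from compound 1 to compound 3. The earlier step gives no size to lean on. A step of a 1.3-fold higher number from compound 3 to compound 4 (0.11 log units; within the scatter) is expected, resting on compound 3 at 233 nM and on the small size of the change. Compound 4 is estimated at 300 nM, within 120 nM to 800 nM.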

Compound 4, half-maximal effective concentration: 198000 nM
Compound 4: the middle estimate sits 660-fold (2.82 log units) below what was measured, outside the stated range (above it).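

In this assay the change from methoxy to ethoxy gives an 850-fold higher number from compound 3 to compound 4 (2.93 log units; beyond the scatter), a large step on the core of compound 3. This is one pair on one core, so it does not show that the same change would have a similar size on any other core in the series. The steps between compound 1 and compound 2 and from either of them to compound 4 cannot be read, because compound 1 and compound 2 each give only a limit: the limit of > 1000 nM in this assay, at which 2 of the 4 values shown sit.

The compounds shown leave open whether a longer chain such as propoxymethyl would follow compound 4 or compound 3. Going by these compounds, how an amine or a carboxylic acid in place of methoxymethyl would read also remains open.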